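Chain length at the aryl ether in two imidazole cores

A few compounds are considered here, and "the series" means these few. Any claim that something is new, unique, unknown or untested is made for them only; others in the source may bear on it.

Measured so far:
compound 1, `C=CCCOc1ncc(-c2ccccc2OC)n1C`: 16000 nM
compound 2, `C=CCCCCOc1ncc(-c2ccccc2OC)n1C`: 9000 nM
compound 3, `C=CCCCCOc1ccccc1-c1cnc(S(=O)(=O)c2ccccc2)n1C`: 63000 nM

In a functional assay on U-373MG ATCC cells (Homo sapiens) for inhibition, read by colorimetric assay and MTT assay, with a stated time of 72 h (on this read-out lower numbers stand for stronger inhibition and higher numbers for weaker inhibition), compound 2 gives 9000 nM and compound 1 gives 16000 nM. The change between them is vinyl in place of but-3-en-1-yl on a saturated chain carbon, two bonds along the chain from an oxygen on an aromatic ring, and the step is a 1.8-fold higher number from compound 2 to compound 1 (0.25 log units; within the scatter). On the same read-out compound 3 gives 63000 nM, the highest number of the three; its gap to compound 1 and to compound 2 is in both cases beyond the scatter. How the core of compound 3 differs from the core shared by compound 1 and compound 2 is not broken down here.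

Compound 4, `C=CCCOc1ccccc1-c1cnc(S(=O)(=O)c2ccccc2)n1C`, has not been measured in this assay. It differs from compound 3 by vinyl in place of but-3-en-1-yl on a saturated chain carbon, two bonds along the chain from an oxygen on an aromatic ring. The place of this change is the same, word for word, as the place of the change from compound 2 to compound 1, so it is taken as the same change, now made on the core of compound 3.

Going by the values given here, the only precedent is the step from compound 2 to compound 1, which lies within the scatter; a step of about the same size is therefore expected from compound 3 to compound 4, namely a 1.6-fold higher number from compound 3 to compound 4 (0.20 log units; within the scatter). This rests on a single pair, and on a different core, so the range is kept wide. Compound 4 is expected to give about 100000 nM in this assay, between 40000 nM and 250000 nM.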

Compound 4, half-maximal inhibitory concentration: > 100000 nM
Compound 4 was reported as a limit; the forecaster's own chance of this, stated with the estimate: 30%; the middle value lies on the limit itself.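

In this assay compound 4 gives > 100000 nM, which is a limit of the assay and not a number. The step on the core of compound 3 can therefore be read only as a floor, an at least 1.5-fold higher number from compound 3 to compound 4 (0.20 log units; that floor lies within the scatter), and this floor is compatible with the earlier step, so nothing here suggests that the shortening from (hex-5-en-1-yl)oxy to (but-3-en-1-yl)oxy behaves differently once carried to the second core: the same change on two cores in this assay, a 1.8-fold higher number (0.25 log units; within the scatter) from compound 2 to compound 1 and an at least 1.5-fold higher number (0.20 log units; that floor lies within the scatter) from compound 3 to compound 4; the limit leaves it open whether they differ. Going by these compounds alone, this does not show that the change transfers with the same size, since the true size of the step on the core of compound 3 stays unknown, there is only one pair on each core, and the reading on that core ends at the top of the measurable range: the limit of > 100000 nM in this assay, at which 1 of the 4 values shown sits.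

The compounds shown leave open how a chain longer than hex-5-en-1-yl, or one of intermediate length such as pent-4-en-1-yl, would read on either core, which would show whether chain length follows any trend at all in this series. They also leave open whether a saturated chain end, or an amine or a carboxylic acid at the end of the chain in place of the terminal double bond, would shift the numbers on either core.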